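Compound 3: methyl for 4-bromophenyl on the thiourea-type nitrogen

This account rests on a few compounds, and the source may have more. Where it says the series, first, only, none or still open, it means among the compounds named here.

In a functional assay on MDA-MB-231 cells (Homo sapiens) for inhibition, read by MTT assay, with a stated time of 48 h (a lower number here means a stronger inhibitor of growth, a higher number a weaker inhibitor of growth), compound 1 `Fc1ccc(NC(=S)Nc2ccc3ncnc(Nc4cccc(Br)c4)c3c2)cc1Cl` gives 300 nM. Compound 2 `S=C(Nc1ccc(Br)cc1)Nc1ccc2ncnc(Nc3cccc(Br)c3)c2c1` gives > 30000 nM in this assay, and this is a limit, not a number. Its standing is therefore known only as a limit: the limit of > 30000 nM in this assay, at which 1 of the 2 values shown sits.

Next in the series is compound 3 `CNC(=S)Nc1ccc2ncnc(Nc3cccc(Br)c3)c2c1`, with the change (methyl in place of 4-bromophenyl on an amide-type nitrogen). Going by the values given here, this puts methyl in place of 4-bromophenyl on an amide-type nitrogen, the same place that varies in the one measured step. That step, an at least 100-fold higher number from compound 1 to compound 2 (2.00 log units; beyond the scatter), put 4-bromophenyl in place of 3-chloro-4-fluorophenyl and was large. It shows that the group on this nitrogen can shift the read-out strongly in this assay, but it gives only the effect of exchanging one aromatic group for another. Among the compounds with values here, no compound with a simple alkyl group on this nitrogen has been measured. A moderate move towards a lower number is expected, and another limit remains possible. The expected change is an at least 3.0-fold lower number from compound 2 to compound 3 (0.47 log units; beyond the scatter). For compound 3 the estimate is 10000 nM, with an expected range of 2000 nM to 30000 nM.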

Compound 3, concentration for 50% growth inhibition: > 30000 nM
Compound 3 gave a limit, no number (the forecaster's own chance of this, stated with the estimate: 35%); middle value at least 3.0-fold (0.47 log units) away from the limit.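

In this assay, methyl in place of 3-chloro-4-fluorophenyl on the amide-type nitrogen gives an at least 100-fold higher number from compound 1 to compound 3 (2.00 log units; beyond the scatter), so the loss is no longer confined to an exchange of one aromatic group for another. A small alkyl group and the 4-bromophenyl group now both fall short of the 3-chloro-4-fluorophenyl group, and among the groups shown on this nitrogen only that group gives a number rather than a limit: the limit of > 30000 nM in this assay, at which 2 of the 3 values shown sit. The step between compound 2 and compound 3 cannot be read, as both values are limits, so these two groups cannot be ranked against each other.

The compounds shown do not tell whether the chlorine or the fluorine of compound 1 matters more, and a phenyl ring carrying only one of these atoms would separate the two. They also leave open whether a non-aromatic group larger than methyl, such as a longer alkyl chain or a chain ending in an amine, would give a number on this nitrogen.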